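From 2-methylbenzyl to 4-bromobenzyl at an unchanged level

This account rests on a few compounds, and the source may have more. Where it says the series, first, only, none or still open, it means among the compounds named here.

In a functional assay on LNCaP cells (Homo sapiens) for inhibition, read by WST assay, with a stated time of 48 h (a higher number here means a weaker inhibitor of growth, a lower number a stronger inhibitor of growth), compound 1 `C=C(C)C(=O)N(Cc1ccccc1C)C(=O)/C=C/c1cc(OC)c(OC)c(OC)c1` gives 10000 nM. Where compound 1 has 2-methylbenzyl, compound 2 `C=C(C)C(=O)NC(=O)/C=C/c1cc(OC)c(OC)c(OC)c1` has hydrogen, and compound 2 gives 10000 nM, so the two stand level. Compound 3 `C=C(C)C(=O)N(Cc1ccc(Br)cc1)C(=O)/C=C/c1cc(OC)c(OC)c(OC)c1` keeps the core of compound 1 but has 4-bromophenyl in place of 2-methylphenyl on a saturated chain carbon bound to an amide-type nitrogen. Among the compounds with values here, only one measured step bears on this change, the replacement of 2-methylbenzyl by hydrogen, and it shows no change at the digits printed from compound 1 to compound 2 (within the scatter). Within the data shown here, that step concerns the same nitrogen substituent, but no measured compound carries a bromine, so it offers only limited guidance. The expected result in this assay is therefore no step beyond the scatter, and the estimated step is a 1.3-fold lower number from compound 1 to compound 3 (0.10 log units; within the scatter). The estimate for compound 3 is 8000 nM, with an expected range of 2500 nM to 15000 nM.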

Compound 3, concentration for 50% growth inhibition: 7700 nM
The estimate for compound 3 lay 1.0-fold (0.02 log units) above the measured number; the range from low to high includes it.
By their numbers in this assay, from the lowest: compounds 3, 1 and 2 (each within the scatter of the next).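

In this assay, within the data shown here, 4-bromophenyl in place of 2-methylphenyl on the saturated chain carbon bound to the amide-type nitrogen gives a 1.3-fold lower number from compound 1 to compound 3 (0.11 log units; within the scatter), which brings a bromine into this series for the first time without a step beyond the scatter. With 4-bromobenzyl in place of hydrogen on the same nitrogen, the result is a 1.3-fold lower number from compound 2 to compound 3 (0.11 log units; within the scatter), so a second substituted benzyl group also stands level with the unsubstituted nitrogen. No measurement at hand says why these groups leave the number where it stands.

All three compounds lie within the scatter of one another, so none of them shows what would move the number at this nitrogen. Going by these compounds, whether an amine, a carboxylic acid or a longer chain in place of 4-bromobenzyl would produce a step beyond the scatter remains open.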